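The source may report more compounds than this note shows. Statements on the series, on what has been measured and on what is new or still open speak of the compounds shown alone.

In a functional assay for agonist activity at G protein-coupled receptor 88 (Homo sapiens), read by HTRF and cAMP accumulation (a higher number here means that more compound is needed for the effect, a lower number that less compound is needed), two compounds have been measured. Compound 1 `CC[C@H](C)[C@H](N)CN(C(=O)[C@@H]1C[C@H]1c1cccc(Cl)c1)c1ccc(-c2ccccc2)cc1` gives 2200 nM, and compound 2 `CC[C@H](C)[C@H](N)CN(C(=O)[C@@H]1C[C@H]1c1nccs1)c1ccc(-c2ccccc2)cc1` gives 210 nM. Going by the values given here, compound 2 therefore stands at the lowest number of the two, and the one step between them, a 10-fold lower number from compound 1 to compound 2 (1.02 log units; beyond the scatter), came from exchanging the whole ring that hangs on the saturated ring carbon.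

Compound 3 `CC[C@H](C)[C@H](N)CN(C(=O)[C@@H]1C[C@H]1c1ncc(C)s1)c1ccc(-c2ccccc2)cc1` keeps everything in compound 2 and adds one small piece: methyl in place of hydrogen on an aromatic carbon. Among the compounds with values here, no measured step touches this kind of change; the only step known swapped one ring for another, and it says nothing about a methyl set on an aromatic carbon next to the ring sulfur. With nothing to lean on, the expectation for compound 3 in this assay is a step of about a 1.1-fold lower number from compound 2 to compound 3 (0.02 log units; within the scatter), which means no move beyond the scatter, and a value near 200 nM, estimated between 70 nM and 600 nM.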

Compound 3, half-maximal effective concentration: 1300 nM
For compound 3 the middle estimate is 6.5-fold (0.81 log units) below the measured one, outside the stated range (above it).
By their numbers in this assay, from the lowest: compound 2; then compounds 3 and 1 (each within the scatter of the next).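

The 5-methyl-1,3-thiazol-2-yl result shows that this ring carbon is not a place where any small addition passes unnoticed in this assay: methyl in place of hydrogen on the aromatic carbon next to the ring sulfur gives a 6.2-fold higher number from compound 2 to compound 3 (0.79 log units; beyond the scatter) and so one added carbon is enough to move the number beyond the scatter. The gain from the ring exchange does not survive this addition, as a 1.7-fold lower number from compound 1 to compound 3 (0.23 log units; within the scatter) leaves the methylated thiazole and 3-chlorophenyl on the saturated ring carbon not separated in this assay. No measurement at hand accounts for the shift.

Going by these compounds, whether the loss belongs to methyl in particular or to any group on this carbon stays open, and a fluorine, a methoxy or a carboxylic acid there would speak to that. Also open, on these data alone, is whether a methyl would have a similar effect on another ring, such as the 3-chlorophenyl of compound 1.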